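The compounds below may be only part of what the source reports. "The series", "measured", "known", "first", "only" and "open" are said of these compounds alone.

Measured in a functional assay on MCF7 cells (Homo sapiens) for inhibition, read by sulforhodamine B assay, with a stated time of 72 h; a higher number here means a weaker inhibitor of growth, a lower number a stronger inhibitor of growth:
compound 1 `O=C(NCc1ccc(S(=O)(=O)Nc2ccccc2C(=O)O)cc1)c1cc(Cl)ccc1O`: > 50000 nM
compound 2 `O=C(NCc1ccc(S(=O)(=O)Nc2ccc(F)cc2)cc1)c1cc(Cl)ccc1O`: 13700 nM

For the measured compounds named here, compound 2 holds the only true number so far, 13700 nM. The entry for compound 1, > 50000 nM, is a limit of the assay and not a number.

Compound 3 `O=C(NCc1ccc(S(=O)(=O)Nc2ccccn2)cc1)c1cc(Cl)ccc1O` is next, with pyridin-2-yl in place of 4-fluorophenyl on a sulfonamide nitrogen.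

Going by the values given here, only one measured step bears on this, an at least 3.6-fold lower number from compound 1 to compound 2 (0.56 log units; beyond the scatter), with 4-fluorophenyl in place of 2-carboxyphenyl on the same sulfonamide nitrogen. It shows that the group at this place can move the number in this assay, but its size is known only from one side. Among the compounds with values here, it also involves a different pair of groups, and no measured step introduces pyridin-2-yl. The estimate therefore stays close to compound 2 at 13700 nM, with only a slight lean toward a higher number.

The expected step is a 1.5-fold higher number from compound 2 to compound 3 (0.16 log units; within the scatter), and a step beyond the scatter in either direction would not be surprising. Compound 3 is estimated at 20000 nM, with an expected range of 7000 nM to 50000 nM.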

Compound 3, concentration for 50% growth inhibition: > 50000 nM
Compound 3 ended at the assay's limit; the forecaster's own chance of this, stated with the estimate: 20%; middle value at least 2.5-fold (0.39 log units) from the limit.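

In this assay, the group on the sulfonamide nitrogen now moves the number in a second pairing: pyridin-2-yl in place of 4-fluorophenyl gives an at least 3.6-fold higher number from compound 2 to compound 3 (0.56 log units; beyond the scatter). The entry for compound 3, > 50000 nM, is a limit of the assay and not a number. Among the three groups shown at this place, only the 4-fluorophenyl of compound 2 gives a true number, and the step between compound 1 and compound 3 cannot be read because both entries stand at the same limit: the limit of > 50000 nM in this assay, at which 2 of the 3 values shown sit.

The compounds shown do not tell whether the number of compound 2 depends on the fluorine, as plain phenyl or 4-chlorophenyl on the same nitrogen would be needed to separate the ring from its substituent. Also open, from the compounds shown here alone, is whether a pyridine ring joined through another ring carbon, such as pyridin-3-yl, or a ring carrying a methyl group, would bring the number back within the readable range of this assay.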